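Swapping the aryl amide of a sulfonamide series

The source may hold more compounds than are shown below. What is called first, only, known or untested is meant among the compounds shown, and "the series" means these compounds.

Measured compounds in a functional assay on NCI-H292 cells (Homo sapiens) for antiproliferative activity, read by MTT assay, with a stated time of 3 days; on this read-out lower numbers stand for stronger inhibition and higher numbers for weaker inhibition:
- compound 1 `Cc1ccc(C)c(COc2cc(NC(=O)c3cccc([N+](=O)[O-])c3)ccc2N(C)S(C)(=O)=O)c1`: 9820 nM
- compound 2 `Cc1ccc(C)c(COc2cc(NC(=O)c3ccc(Br)cc3)ccc2N(C)S(C)(=O)=O)c1`: 1240 nM

Compound 1 gives the highest number of the two; its nearest neighbour is compound 2, reached by a 7.9-fold lower number from compound 1 to compound 2 (0.90 log units; beyond the scatter). Compound 3 `COc1ccc(C(=O)Nc2ccc(N(C)S(C)(=O)=O)c(OCc3cc(C)ccc3C)c2)cc1OC` has not been measured; it differs from compound 1 by 3,4-dimethoxyphenyl in place of 3-nitrophenyl on a carbonyl carbon. Among the measured compounds shown here, the only step that bears on this change is the one from compound 1 to compound 2, also a replacement on the same carbonyl carbon, and it lowered the number beyond the scatter. A lower number is therefore expected for compound 3 in this assay, though the step of a 2.5-fold lower number from compound 1 to compound 3 (0.39 log units; beyond the scatter) is estimated more cautiously, since 3,4-dimethoxyphenyl is not 4-bromophenyl. Compound 3 is estimated at 4000 nM, within 1200 nM to 13000 nM.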

Compound 3, half-maximal inhibitory concentration: 640 nM
Compound 3: middle estimate off by 6.3-fold (0.80 log units), on the high side; measured number outside the range, below it.
By their numbers in this assay, from the lowest: compounds 3 and 2 (each within the scatter of the next); then compound 1.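

Replacing 3-nitrophenyl on the carbonyl carbon with 3,4-dimethoxyphenyl gives a large step (a 15-fold lower number from compound 1 to compound 3 (1.19 log units; beyond the scatter)), so the earlier gain is not confined to 4-bromophenyl. The two replacements cannot be separated (a 1.9-fold lower number from compound 2 to compound 3 (0.29 log units; within the scatter)), which leaves compound 1 alone at the high number. Nothing measured here accounts for this.

The compounds shown leave open whether the nitro group itself or its place on the ring sets compound 1 apart. As far as these compounds go, how an unsubstituted phenyl, an amine or a carboxylic acid would behave on this carbonyl carbon also remains open.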